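The compounds below may be only part of what the source reports. "The series", "measured", "known", "first", "only" and "open" are said of these compounds alone.

Measured compounds in the series:

- compound 1, `CCOC(=O)c1sc2nc(SC)nc(-c3cccc(OC)c3)c2c1N`: 4.2%
- compound 2, `COc1cccc(-c2nc(SC)nc3sc(C(=O)N(C)C(C)(C)C)c(N)c23)c1`: 47.8%
- compound 3, `CCNC(=O)c1sc2nc(SC)nc(-c3cccc(OC)c3)c2c1N`: 26.9%

All three were run in a functional assay on HEK293 cells for agonist activity at lutropin-choriogonadotropic hormone receptor (Homo sapiens), read by cAMP accumulation; a higher number here means a larger maximal response, a lower number a smaller maximal response. Compound 1 gives the lowest of the three numbers; the nearest is compound 3, the furthest compound 2, and both steps away from compound 1 lie beyond the scatter: a number 43.6 percentage points higher from compound 1 to compound 2 (beyond the scatter) and a number 22.7 percentage points higher from compound 1 to compound 3 (beyond the scatter). Between the two amides the gap is a number 20.9 percentage points lower from compound 2 to compound 3 (beyond the scatter).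

Compound 4, `COc1cccc(-c2nc(SC)nc3sc(C(=O)OC(C)(C)C)c(N)c23)c1`, has not yet been measured in this assay. It differs from compound 1 by tert-butyl in place of ethyl on an oxygen next to a carbonyl group. The shared core and the carbonyl group are kept.

Neither measured step bears on this change directly: both replace the ethoxy on a carbonyl carbon with an amino group, whereas compound 4 keeps an ester and only exchanges ethyl for tert-butyl on the oxygen. The large step to compound 2 and the modest step to compound 3 show that the group on the carbonyl carbon matters in this assay, but they give no reading for an ester-to-ester exchange. The expected step is therefore small, and a number 7.8 percentage points higher from compound 1 to compound 4 (within the scatter) is estimated as a slight rise that may not exceed the scatter. Compound 4 is expected to give 12%, within a range from 2% to 30%.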

Compound 4, largest response reached (reported as efficacy), in percent of the reference or control that the assay uses: 23.8%
Compound 4: the middle estimate sits 11.8 percentage points below what was measured, and the stated range covers the measured number.
By their numbers in this assay, from the lowest: compound 1; then compounds 4 and 3 (each within the scatter of the next); then compound 2.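

In this assay, the ester is not a fixed low point of the series: with the shared core and the carbonyl group kept, tert-butyl in place of ethyl on the oxygen gives a number 19.6 percentage points higher from compound 1 to compound 4 (beyond the scatter) as the step, so the group on that oxygen alone can shift the maximal response. An amide is also not needed to reach the level of compound 3, as tert-butoxy in place of ethylamino gives a number 3.1 percentage points lower from compound 3 to compound 4 (within the scatter) and leaves the two compounds within the scatter of each other, yet tert-butoxy in place of methyl(tert-butyl)amino gives a number 24 percentage points lower from compound 2 to compound 4 (beyond the scatter) and leaves compound 2 with the highest number of the four. No measured data account for any of these differences.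

Open, going by these compounds, is whether the response changes stepwise along the ester series, which an isopropyl ester would test, and how a carboxylic acid at the same carbonyl carbon behaves. Also open, on these data alone, is what the methyl on the amide nitrogen of compound 2 contributes, which a tert-butylamino amide carrying the amide hydrogen would separate from the contribution of the tert-butyl group.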